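A few compounds are considered here, and "the series" means these few. Any claim that something is new, unique, unknown or untested is made for them only; others in the source may bear on it.

Working notes on the series.

Compound 1 `C#Cc1nc2ccccc2n1C` and compound 2 `C#Cc1nc2ccccc2o1` share the ethynyl group on cores that differ; the difference between the two cores is not broken down here. In a functional assay on NCI-H522 cells (Homo sapiens) for cytotoxicity, with a stated time of 3 days (a lower number here means a stronger inhibitor, a higher number a weaker inhibitor), compound 1 gives 8140 nM. In this assay compound 2 gives 1260 nM, the lowest of the two numbers, with compound 1 the nearest. Compound 3 `Cn1c(Br)nc2ccccc21` carries the change (bromo in place of ethynyl on an aromatic carbon). In this assay compound 3 reaches only a limit, > 40000 nM, which is the limit of > 40000 nM in this assay, at which 1 of the 3 values shown sits. The step is an at least 4.9-fold higher number from compound 1 to compound 3 (0.69 log units; beyond the scatter), and because the limit of > 40000 nM in this assay, at which 1 of the 3 values shown sits, its full size is not known.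

Compound 4 `Brc1nc2ccccc2o1` is the unmeasured partner, differing from compound 2 by bromo in place of ethynyl on an aromatic carbon. This is the same kind of change as that from compound 1 to compound 3, but at a different place: in compound 4 the carbon sits in a five-membered aromatic ring with 1 nitrogen and 1 oxygen, next to the ring nitrogen and next to the ring oxygen, whereas in compound 3 it sits in a ring with 2 nitrogen, between two ring nitrogen atoms, next to the ring atom that bears a methyl group.

In this assay a step of similar or larger size is expected from compound 2 to compound 4, a 9.5-fold higher number from compound 2 to compound 4 (0.98 log units; beyond the scatter), resting on the step from compound 1 to compound 3 an at least 4.9-fold higher number from compound 1 to compound 3 (0.69 log units; beyond the scatter). Compound 4 is therefore estimated at 12000 nM, between 4000 nM and 40000 nM.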

Compound 4, half-maximal inhibitory concentration: > 40000 nM
Compound 4 ended at the assay's limit (the forecaster's own chance of this, stated with the estimate: 30%); middle value at least 3.3-fold (0.52 log units) from the limit.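

Bromo in place of ethynyl on an aromatic carbon again gives a higher number in this assay, here an at least 31-fold higher number from compound 2 to compound 4 (1.50 log units; beyond the scatter), so the direction of the change carries over from the core of compound 1 to the core of compound 2. In this assay compound 4 gives > 40000 nM, which is a limit of the assay, so the full size of the new step is not known: the limit of > 40000 nM in this assay, at which 2 of the 4 values shown sit. The direction is therefore all that can be carried across, and nothing shows whether the change is larger on one core than on the other: the same change on two cores in this assay, an at least 4.9-fold higher number (0.69 log units; beyond the scatter) from compound 1 to compound 3 and an at least 31-fold higher number (1.50 log units; beyond the scatter) from compound 2 to compound 4; the limit leaves it open whether they differ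

From the compounds shown here alone, only ethynyl and bromo are compared at this carbon, so it stays open whether an amine, a nitrile or a longer alkyne chain there would give numbers closer to those of the ethynyl compounds. With only two cores and a single cell line shown, it also stays open whether the same direction holds on other cores or in other cells.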